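Ethyl for bromo on the shared core

The source may hold more compounds than are shown below. What is called first, only, known or untested is meant among the compounds shown, and "the series" means these compounds.

Two compounds of the series have been run in a functional assay on L1210 cells (Mus musculus) for cytotoxicity; on this read-out higher numbers stand for weaker inhibition and lower numbers for stronger inhibition. Compound 1 `C=C1C(n2cc(Br)c(=O)[nH]c2=O)O[C@H](CO)[C@@H]1O` returns only a limit of the assay in this assay, at > 100 ug/mL. Compound 2 `C=C1C(n2cc(Br)c(N)nc2=O)O[C@H](CO)[C@@H]1O` likewise returns only a limit in this assay, at > 100 ug/mL. Both values shown thus sit at one and the same limit, as the evidence records: the limit of > 100 ug/mL in this assay, at which 2 of the 2 values shown sit. Going by the values given here, compound 2 has no number of its own, and no step between measured compounds is available in this set.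

Compound 3 `C=C1C(n2cc(CC)c(N)nc2=O)O[C@H](CO)[C@@H]1O` differs from compound 2 in one place: ethyl in place of bromo on an aromatic carbon. The measured pair, compound 1 and compound 2, both ending at the limit, gives no direction for this change. The expectation for compound 3 is that the step of a number no higher from compound 2 to compound 3 (the limit leaves the size open) is none beyond the scatter. On that basis compound 3 is estimated at 100 ug/mL in this assay, with a range from 30 ug/mL to 300 ug/mL, and the most likely outcome is that a limit will again be reported rather than a number.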

Compound 3, half-maximal inhibitory concentration: > 100 ug/mL
Compound 3 gave a limit, no number; the forecaster's own chance of this, stated with the estimate: 85%; the middle value lies on the limit itself.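

Compound 2 and compound 3 both end at a limit, so no step can be read for ethyl in place of bromo on the aromatic carbon: the limit of > 100 ug/mL in this assay, at which 3 of the 3 values shown sit.

The compounds shown leave open whether any change on the shared core would give a true number in this assay, and how the three compounds rank beyond that limit.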